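This account rests on a few compounds, and the source may have more. Where it says the series, first, only, none or still open, it means among the compounds named here.

Measured in a functional assay on HCT-116 cells (Homo sapiens) for inhibition, read by MTT assay, with a stated time of 48 h; a higher number here means a weaker inhibitor, a lower number a stronger inhibitor:
compound 1 `COc1cc(-c2nccn3cc(-c4ccc(F)cc4)nc23)cc(OC)c1OC`: 263 nM
compound 2 `COc1cc(-c2nccn3cc(-c4ccccc4)nc23)cc(OC)c1OC`: 266 nM

Within the data shown here, only these two compounds have numbers so far, and compound 2 cannot be told apart from compound 1, as their values lie within the scatter of each other. Compound 3 `COc1cc(-c2nccn3cc(-c4ccc(C(F)(F)F)cc4)nc23)cc(OC)c1OC` differs from compound 2 by trifluoromethyl in place of hydrogen on an aromatic carbon. Among the measured compounds shown here, the only measured step that bears on this change is a 1.0-fold higher number from compound 1 to compound 2 (0.00 log units; within the scatter), hydrogen in place of fluoro on an aromatic carbon, and it lies within the scatter. For the measured compounds named here, no measured compound carries trifluoromethyl, so the data give no direction and one step is thin support. No shift beyond the scatter is therefore expected in this assay. The expected step is a 1.1-fold higher number from compound 2 to compound 3 (0.05 log units; within the scatter). For compound 3 the estimated value is 300 nM, with an expected range of 100 nM to 900 nM.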

Compound 3, half-maximal inhibitory concentration: > 10000 nM
Compound 3: only a limit was reported; the forecaster's own chance of this, stated with the estimate: 2%; at least 33-fold (1.52 log units) between middle value and limit.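

In this assay, the aromatic carbon para to a large group proves sensitive to what it carries: hydrogen and fluoro could not be told apart there, yet trifluoromethyl gives an at least 37-fold higher number from compound 2 to compound 3 (1.57 log units; beyond the scatter) and an at least 38-fold higher number from compound 1 to compound 3 (1.58 log units; beyond the scatter). Compound 3 reads > 10000 nM, which is a limit and not a number, the only one among the compounds shown: the limit of > 10000 nM in this assay, at which 1 of the 3 values shown sits. The flat result for the hydrogen and fluoro pair therefore does not extend to every substituent at this carbon, and the data shown do not say what sets trifluoromethyl apart.

Still open, from the compounds shown here alone, is how other groups at this carbon behave, such as chloro, methyl, an amine or a carboxylic acid. Also open, going by these compounds, is whether trifluoromethyl at another carbon of this ring gives the same loss.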